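Solubility Across Three Aryl Variants on a Shared Core

The source may report more compounds than this note shows. Statements on the series, on what has been measured and on what is new or still open speak of the compounds shown alone.

Compound 1 `CNc1nc(NCCCN(C)C)c2sc(-c3ccc(NS(C)(=O)=O)cc3)cc2n1` and compound 2 `CNc1nc(NCCCN(C)C)c2sc(-c3ccc(OC)nc3)cc2n1` carry the same core and differ only in the aromatic group attached to it. In a physicochemical assay for solubility, in phosphate buffer, at pH 6.5 (on this read-out higher numbers stand for higher solubility and lower numbers for lower solubility), compound 1 gives 25 ug/mL, and in this assay compound 2 gives 25 ug/mL; the two values are level at the digits shown and lie within the usual scatter, so this pair supports no statement of order between them. Compound 3 `CNc1nc(NCCCN(C)C)c2sc(-c3ccc(C(C)=O)cc3)cc2n1` has not yet been measured in this assay. It differs from compound 2 by 4-acetylphenyl in place of 6-methoxypyridin-3-yl on an aromatic carbon. Within the data shown here, no measured step covers a change of this kind, so the expectation rests only on the two values at hand and on the change itself. The step of a 1.7-fold lower number from compound 2 to compound 3 (0.22 log units; within the scatter) is expected to be small and downward, and it may well fall within the scatter. Compound 3 is estimated at 15 ug/mL, with a range from 5 ug/mL to 50 ug/mL.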

Compound 3, solubility: 12.5 ug/mL
Estimate against measurement, compound 3: 1.2-fold (0.08 log units) above; the measured number falls inside the stated range.
By their numbers in this assay, from the lowest: compounds 3, 1 and 2 (each within the scatter of the next).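

At this place, on an aromatic carbon next to the ring sulfur, 4-acetylphenyl in place of 6-methoxypyridin-3-yl gives a 2.0-fold lower number from compound 2 to compound 3 (0.30 log units; within the scatter) in this assay, while acetyl in place of methanesulfonamido on the same phenyl ring gives a 2.0-fold lower number from compound 1 to compound 3 (0.30 log units; within the scatter). Neither step separates the compounds, so the three aromatic groups shown here cannot be told apart on this read-out, whether the ring is all carbon or holds a hetero atom. No measurement at hand accounts for the result, and none assigns it a cause.

The compounds shown leave open whether a carboxylic acid or a morpholine on this aromatic ring would carry the number beyond the scatter. They also leave open whether any change elsewhere on the shared core would do so.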